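The compounds below may be only part of what the source reports. "The series", "measured", "known", "first", "only" and "open" are said of these compounds alone.

Compound 1 `COc1ccc(/C(=C(/CCN=[N+]=[N-])c2ccccc2)c2ccccc2)cc1` is the starting point, and in a functional assay on MCF7 cells (Homo sapiens) for cytotoxicity, read by MTT assay, with a stated time of 72 h (on this read-out higher numbers stand for weaker inhibition and lower numbers for stronger inhibition), compound 1 gives "not active" (no number reported). Compound 2 `COc1ccc(/C(=C(/CCNC(=O)NC2CCCCC2)c2ccccc2)c2ccccc2)cc1` carries a cyclohexylamino urea, and in this assay compound 2 gives 37200 nM. Compound 3 `COc1ccc(/C(=C(/CCNC(=O)N2CCOCC2)c2ccccc2)c2ccccc2)cc1` is reported in this assay only as a limit, > 50000 nM. The step of an at least 1.3-fold higher number from compound 2 to compound 3 (0.12 log units; that floor lies within the scatter) is therefore a floor rather than a number. Compound 3 thus stands at the weak end of what is shown, at the limit of > 50000 nM in this assay, at which 1 of the 3 values shown sits, with compound 1 the one other entry without a single number. Compound 4 `COc1ccc(/C(=C(/CCNC(=O)N2CCCC2)c2ccccc2)c2ccccc2)cc1` differs from compound 3 by pyrrolidin-1-yl in place of morpholin-4-yl on a carbonyl carbon. Within the data shown here, the only measured step at that carbonyl carbon stayed within the scatter, so in this assay no step beyond the scatter is expected for compound 4, which is estimated at 45000 nM (range 20000 nM to 100000 nM), a change of an at least 1.1-fold lower number from compound 3 to compound 4 (0.04 log units; that floor lies within the scatter).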

Compound 4, half-maximal inhibitory concentration: > 50000 nM
Compound 4 was reported as a limit; the forecaster's own chance of this, stated with the estimate: 50%; middle value at least 1.1-fold (0.04 log units) away from the limit.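

Compound 4 is again only a limit in this assay, so pyrrolidin-1-yl, like morpholin-4-yl, leaves the urea without a number: the limit of > 50000 nM in this assay, at which 2 of the 4 values shown sit. The step between these two limits cannot be read, so the two rings cannot be ordered. Against the cyclohexylamino urea there is an at least 1.3-fold higher number from compound 2 to compound 4 (0.12 log units; that floor lies within the scatter) and thus still no step on this carbonyl carbon shown beyond the scatter. Going by these compounds, what stays open is whether a phenylamino or a piperidin-1-yl group on that carbonyl carbon would give a number in this assay, and how far compound 3 and compound 4 really lie apart.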